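Cyclopentyl for phenyl on the terminal amide nitrogen

A few compounds are considered here, and "the series" means these few. Any claim that something is new, unique, unknown or untested is made for them only; others in the source may bear on it.

Compound 1 `C#CCn1cc(C(=O)NC(CC(=O)Nc2ccccc2)c2ccccc2)c(=O)c2cc(F)c(Cl)nc21` stands at the weaker end of the two numbers in hand: in an ADME assay on NIH3T3 cells (Mus musculus) for cytotoxicity, read by MTT assay, with a stated time of 72 h (a lower number here means a stronger inhibitor, a higher number a weaker inhibitor), compound 1 gives 9700 nM. Compound 3 `C#CCn1cc(C(=O)NC(CC(=O)Nc2ccccn2)c2ccccc2)c(=O)c2cc(F)c(Cl)nc21`, which carries pyridin-2-yl on the same amide nitrogen, gives 4200 nM, and the step is a 2.3-fold lower number from compound 1 to compound 3 (0.36 log units; beyond the scatter). Compound 2 `C#CCn1cc(C(=O)NC(CC(=O)NC2CCCCC2)c2ccccc2)c(=O)c2cc(F)c(Cl)nc21`, with cyclohexyl on that nitrogen, is reported as "not active" (no number reported). Among the compounds with values here, no single-place step is set out between compound 1 and compound 2, so only the two readings themselves can be placed side by side: the phenyl member returns a number, the saturated six-membered ring member returns none.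

Compound 4 `C#CCn1cc(C(=O)NC(CC(=O)NC2CCCC2)c2ccccc2)c(=O)c2cc(F)c(Cl)nc21` makes the change (cyclopentyl in place of phenyl on an amide-type nitrogen). Within the data shown here, no measured pair covers exactly this change. The nearest guide is the pairing of compound 1 with compound 2, given that compound 2 reads "not active" (no number reported) while compound 1 reads 9700 nM; a non-aromatic carbocycle on this nitrogen has so far meant loss of a measurable number. Compound 4 is therefore expected to be weaker than compound 1, by an estimated 2.6-fold higher number from compound 1 to compound 4 (0.41 log units; beyond the scatter), with a real chance that only an inactive call results. The working estimate for compound 4 is 25000 nM, with a range of 8000 nM to 80000 nM.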

Compound 4, half-maximal inhibitory concentration: 2400 nM
The estimate for compound 4 lay 10-fold (1.02 log units) above the measured number; measured number outside the range, below it.
By their numbers in this assay, from the lowest: compounds 4 and 3 (each within the scatter of the next); then compound 1.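

In this assay, an aromatic ring on this amide-type nitrogen is not needed for a measurable number, and the one-place change to cyclopentyl gives a 4.0-fold lower number from compound 1 to compound 4 (0.61 log units; beyond the scatter). Cyclopentyl and pyridin-2-yl are not separated at this position, since a 1.8-fold lower number from compound 3 to compound 4 (0.24 log units; within the scatter) leaves the pair inside the usual scatter, so the two members with a lower number than the phenyl member carry quite different rings. Within the data shown here, the earlier reading that a non-aromatic ring of carbon only on this nitrogen costs a measurable number no longer holds as a general pattern: compound 4 goes against it, while compound 2, with cyclohexyl, still reads "not active" (no number reported), and that contrast between the two saturated rings is the sharpest feature of the position so far.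

Still open, going by these compounds, is how an open-chain group such as n-butyl, or a ring bearing an amine such as piperidin-4-yl, would read on this same nitrogen, and whether cyclobutyl or cycloheptyl would follow cyclopentyl or cyclohexyl. No measurement in hand accounts for the difference between these rings.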